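The source may hold more compounds than are shown below. What is called first, only, known or untested is meant among the compounds shown, and "the series" means these compounds.

The measured compounds:

Compound 1 `CCCc1nc(-c2ccccc2)c(CNCCCN2CCN(c3ccc(F)cc3)CC2)o1`: in an assay on HEK293 cells for inhibition of Voltage-dependent T-type calcium channel subunit alpha-1G (Homo sapiens), read by patch clamp (a higher number here means a weaker inhibitor, a lower number a stronger inhibitor), compound 1 gives 3210 nM
Compound 2 `CCCc1nc(-c2ccccc2)c(CNCCCN2CCN(c3ccccc3Cl)CC2)o1`: in this assay compound 2 gives 2800 nM
Compound 3 `CCCc1nc(-c2ccccc2)c(CNCCCN2CCN(c3cccc(C)c3)CC2)o1`: in this assay compound 3 gives 1190 nM

All three share one core and differ only in the aryl group on the ring nitrogen. Compound 3 carries the lowest number of the three: a 2.7-fold lower number from compound 1 to compound 3 (0.43 log units; beyond the scatter) and a 2.4-fold lower number from compound 2 to compound 3 (0.37 log units; beyond the scatter), both beyond the scatter, whereas a 1.1-fold lower number from compound 1 to compound 2 (0.06 log units; within the scatter) lies within it.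

Compound 4 `CCCc1nc(-c2ccccc2)c(CNCCCN2CCN(c3ccc(Cl)cc3)CC2)o1` has not been measured. It differs from compound 3 in one place: 4-chlorophenyl in place of 3-methylphenyl on an amine nitrogen in a ring. The two steps that reach compound 3 both bear on this change, since each replaces one halogen- or methyl-bearing phenyl by another; the 4-fluorophenyl of compound 1 is the closest of the measured groups to the 4-chlorophenyl entering. A modest rise in the number is therefore expected in this assay, with compound 4 estimated to sit between compound 3 and compound 1, a step of a 1.8-fold higher number from compound 3 to compound 4 (0.27 log units; within the scatter).

Compound 4 is estimated at 2200 nM, with a range from 900 nM to 5000 nM.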

Compound 4, half-maximal inhibitory concentration: 1310 nM
Beside the measured number, compound 4's estimate is 1.7-fold (0.23 log units) above it; the range from low to high includes it.
By their numbers in this assay, from the lowest: compounds 3 and 4 (each within the scatter of the next); then compounds 2 and 1 (each within the scatter of the next).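

In this assay the change from 3-methylphenyl to 4-chlorophenyl on the amine nitrogen in a ring makes no difference beyond the scatter (a 1.1-fold higher number from compound 3 to compound 4 (0.04 log units; within the scatter)), so two groups with different atoms give matching numbers here. Within the data shown here, compound 4 also gives the first comparison of one halogen in two arrangements, 4-chlorophenyl in place of 2-chlorophenyl (a 2.1-fold lower number from compound 2 to compound 4 (0.33 log units; beyond the scatter)), and the first direct exchange of one halogen for another, chloro in place of fluoro on an aromatic carbon (a 2.5-fold lower number from compound 1 to compound 4 (0.39 log units; beyond the scatter)), and both steps lie beyond the scatter. No supporting data explain why these changes act as they do.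

The compounds shown leave open whether 3-chlorophenyl or 4-methylphenyl would match compound 3 and compound 4. They also leave open what an unsubstituted phenyl or a pyridine ring would give at this place.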